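Dropping the Ethylcarbamoyl Group from Compound 3

The compounds below may be only part of what the source reports. "The series", "measured", "known", "first", "only" and "open" are said of these compounds alone.

Measured compounds:
compound 1, `CCOC(=O)C1=Cc2ccc(OC)cc2OC1c1cc(OC)c(OC)c(OC)c1`: 25000 nM
compound 2, `COc1ccc2c(c1)OC(c1cc(OC)c(OC)c(OC)c1)C(C(=O)O)=C2`: > 50000 nM
compound 3, `CCNC(=O)C1=Cc2ccc(OC)cc2OC1c1cc(OC)c(OC)c(OC)c1`: > 50000 nM

In a functional assay for inhibition of nuclear factor NF-kappa-B complex (Homo sapiens) (a higher number here means a weaker inhibitor, a lower number a stronger inhibitor), compound 1 gives 25000 nM. Compound 2 reports no number, only the limit > 50000 nM of the measurement. Compound 3 likewise reports only a limit, > 50000 nM. Compound 3 therefore sits at the limit of > 50000 nM in this assay, at which 2 of the 3 values shown sit, and the numbers place it no more precisely than that.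

Two steps can be read. The change of hydrogen in place of ethyl on an oxygen next to a carbonyl group gives an at least 2.0-fold higher number from compound 1 to compound 2 (0.30 log units; that floor lies within the scatter). The change of ethylamino in place of ethoxy on a carbonyl carbon gives an at least 2.0-fold higher number from compound 1 to compound 3 (0.30 log units; that floor lies within the scatter). The step that the two limits leave unreadable from compound 2 to compound 3 cannot be sized, since both ends are limits.

Compound 4, `COc1ccc2c(c1)OC(c1cc(OC)c(OC)c(OC)c1)C=C2`, differs from compound 3 by hydrogen in place of ethylcarbamoyl on a double-bonded ring carbon. Among the measured compounds shown here, no measured step removes the carbonyl-bearing group outright, so the two readable steps bear on it only loosely: each change at that group pushed the value to the limit. Compound 4 is therefore expected to stay near the limit, with a step that the limit leaves unreadable from compound 3 to compound 4 estimated as no step beyond the scatter. The estimate for compound 4 is 60000 nM, within a range from 15000 nM to 200000 nM.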

Compound 4, half-maximal inhibitory concentration: 17700 nM
Beside the measured number, compound 4's estimate is 3.4-fold (0.53 log units) above it; low and high end bracket the measured number.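

In this assay, only compound 1 and compound 4 give a number rather than a limit among the changes shown at this double-bonded ring carbon, while compound 2 and compound 3 carry limits: the limit of > 50000 nM in this assay, at which 2 of the 4 values shown sit. Hydrogen in place of ethylcarbamoyl gives an at least 2.8-fold lower number from compound 3 to compound 4 (0.45 log units; beyond the scatter), and hydrogen in place of carboxy gives an at least 2.8-fold lower number from compound 2 to compound 4 (0.45 log units; beyond the scatter), so compound 4 shows that this carbon needs no carbonyl-bearing group for a number to be read at all. Hydrogen in place of ethoxycarbonyl gives a 1.4-fold lower number from compound 1 to compound 4 (0.15 log units; within the scatter), so the ethoxycarbonyl group of compound 1 shows no readable gain over plain hydrogen, and the ethylcarbamoyl and carboxy groups are the two that stand apart from hydrogen here.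

On these data alone, whether a methyl group, a hydroxymethyl group or a nitrile on this carbon would sit with compound 4 or at the limit stays open. Also open, as far as these compounds go, is whether any group at this position can take the number clearly lower than hydrogen does, and how far past their limits compound 2 and compound 3 really lie.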